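The source may hold more compounds than are shown below. What is called first, only, known or untested is meant among the compounds shown, and "the series" means these compounds.

Three compounds share one core. Compound 1 `CCOC(=O)c1sc(-c2cccc(NC(=O)c3cccc(F)c3)c2)nc1Nc1ccc(N2CCN(C)CC2)cc1` is the only one with a result: in a functional assay on Ramos cells (Homo sapiens) for antiproliferative activity, read by CCK-8 assay, with a stated time of 72 h (a higher number here means a weaker inhibitor, a lower number a stronger inhibitor), compound 1 gives 12800 nM. Compound 2 `CCOC(=O)c1sc(-c2cccc(NC(=O)c3ccc(Cl)cc3)c2)nc1Nc1ccc(N2CCN(C)CC2)cc1` stands without a number: in this assay compound 2 gives "not determined" (no result reported), so there is no measured anchor for the step that follows. Compound 3 `CCOC(=O)c1sc(-c2cccc(NC(=O)c3ccc(F)c(Cl)c3)c2)nc1Nc1ccc(N2CCN(C)CC2)cc1` differs from compound 2 by a single change, (3-chloro-4-fluorophenyl in place of 4-chlorophenyl on a carbonyl carbon), with 3-chloro-4-fluorophenyl in place of 4-chlorophenyl on a carbonyl carbon. Among the compounds with values here, no measured pair in this set shows what such a change does, and nothing else in the data separates these two compounds, so no step beyond the usual scatter is expected in this assay in either direction. Within the data shown here, the only guide to the level is compound 1 with its 12800 nM. For compound 3 a value of 10000 nM is estimated, in a range from 2500 nM to 40000 nM, with a real chance that only a limit is reported.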

Compound 3, half-maximal inhibitory concentration: 29200 nM
Beside the measured number, compound 3's estimate is 2.9-fold (0.47 log units) below it; low and high end bracket the measured number.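

In this assay, the phenyl group on the carbonyl carbon now has a readable step: 3-chloro-4-fluorophenyl in place of 3-fluorophenyl gives a 2.3-fold higher number from compound 1 to compound 3 (0.36 log units; beyond the scatter), a modest change beyond the usual scatter and toward weaker inhibition. This shows that the number responds to the halogen pattern on that phenyl group, at least for this one pair, whereas compound 1 alone gave only a level. Compound 2 has no result, so its step to compound 3 cannot be read, and nothing available accounts for the step from compound 1.

The compounds shown leave open whether a lower number can be reached at this position, for example with a methoxy group, an amine or a carboxylic acid on the phenyl ring. They also leave open how a 3-chlorophenyl or an unsubstituted phenyl group would compare on the same carbonyl carbon.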